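The compounds below may be only part of what the source reports. "The series", "measured", "known", "first", "only" and "open" are said of these compounds alone.

Measured so far in a functional assay on MCF7 cells (Homo sapiens) for antiproliferative activity, read by MTT assay, with a stated time of 72 h; a lower number here means a stronger inhibitor, a higher number a weaker inhibitor:
compound 1 `CCn1c(C(=O)NCCC(=O)OC)ccc1C(CC)(CC)c1ccc(C#CC(O)(CC)CC)c(C)c1`: > 50000 nM
compound 2 `CCN(CC)CCCNC(=O)c1ccc(C(CC)(CC)c2ccc(C#CC(O)(CC)CC)c(C)c2)n1CC`: 17800 nM
compound 3 `CCn1cc(C(CC)(CC)c2ccc(C#CC(O)(CC)CC)c(C)c2)cc1C(=O)NCC(=O)OC`: 26500 nM

In this assay compound 1 reaches only a limit, > 50000 nM, and no number; this is the limit of > 50000 nM in this assay, at which 1 of the 3 values shown sits. Compound 2 gives 17800 nM. Compound 3 gives 26500 nM, a value that lies within the usual scatter of that of compound 2. The step of an at least 2.8-fold lower number from compound 1 to compound 2 (0.44 log units; beyond the scatter) went with (diethylamino)methyl in place of methoxycarbonyl on a saturated chain carbon, two bonds along the chain from an amide-type nitrogen. How the core of compound 1 differs from the core of compound 3 is not broken down here. Compound 4 `CCN(CC)CCNC(=O)c1cc(C(CC)(CC)c2ccc(C#CC(O)(CC)CC)c(C)c2)cn1CC` is not yet measured and differs from compound 3 by (diethylamino)methyl in place of methoxycarbonyl on a saturated chain carbon bound to an amide-type nitrogen. This is the same kind of change as from compound 1 to compound 2, but the place differs: there it sits on a saturated chain carbon, two bonds along the chain from an amide-type nitrogen, here on a saturated chain carbon bound to an amide-type nitrogen. Resting on an at least 2.8-fold lower number from compound 1 to compound 2 (0.44 log units; beyond the scatter), a step of about a 2.9-fold lower number from compound 3 to compound 4 (0.47 log units; beyond the scatter) is expected in this assay. Compound 4 is accordingly estimated at 9000 nM, most likely between 3000 nM and 30000 nM.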

Compound 4, half-maximal inhibitory concentration: 1800 nM
Compound 4: the middle estimate sits 5.0-fold (0.70 log units) above what was measured, outside the stated range (below it).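

In this assay the exchange of methoxycarbonyl for (diethylamino)methyl gives a 15-fold lower number from compound 3 to compound 4 (1.17 log units; beyond the scatter) on this core, so the number falls on both cores, and the two steps compare as follows: the same change on two cores in this assay, an at least 2.8-fold lower number (0.44 log units; beyond the scatter) from compound 1 to compound 2 and a 15-fold lower number (1.17 log units; beyond the scatter) from compound 3 to compound 4; the limit leaves it open whether they differ. Compound 1 gives only a limit and no number, which is why the size of the first step stays unsettled: the limit of > 50000 nM in this assay, at which 1 of the 4 values shown sits. The direction of the change thus carried over between these two cores, but its size cannot be called the same or different, and two cores do not establish a rule for others.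

The compounds shown leave open how a carboxylic acid in place of methoxycarbonyl would read. They also leave open how a piperidine in place of the diethylamino group would read on either core.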